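This account rests on a few compounds, and the source may have more. Where it says the series, first, only, none or still open, it means among the compounds named here.

Compound 1 `COC1(c2csc(Sc3ccc4c(c3)CC/C4=N\OCC#N)c2)CCOCC1` gives 40 nM in a functional assay (blood) for inhibition, with Homo sapiens as the target; on this read-out higher numbers stand for weaker inhibition and lower numbers for stronger inhibition; compound 3 `COC1(c2csc(Sc3ccc4c(c3)CC/C4=N\O)c2)CCOCC1` gives 130 nM; compound 2 `COC1(c2cc(F)cc(Sc3ccc4c(c3)CC/C4=N\O)c2)CCOCC1` gives 290 nM, the highest of the three numbers.

Compound 1 and compound 3 share a core and differ by cyanomethyl in place of hydrogen on an oxygen; this change gave a 3.3-fold lower number from compound 3 to compound 1 (0.51 log units; beyond the scatter). Compound 2 stands on a different core, and the difference between the cores of compound 2 and compound 3 is not broken down here. Compound 4 `COC1(c2cc(F)cc(Sc3ccc4c(c3)CC/C4=N\OCC#N)c2)CCOCC1` is not yet measured; it differs from compound 2 by cyanomethyl in place of hydrogen on an oxygen, the same change that took compound 3 to compound 1. Resting on that single earlier step, compound 4 is expected to show a step of about a 3.3-fold lower number from compound 2 to compound 4 (0.52 log units; beyond the scatter) in this assay. Compound 4 is accordingly estimated at 88 nM, with a likely span from 40 nM to 200 nM.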

Compound 4, half-maximal inhibitory concentration: 30 nM
Beside the measured number, compound 4's estimate is 2.9-fold (0.47 log units) above it; the whole stated range lies above it.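

On the second core, cyanomethyl in place of hydrogen on an oxygen gave a 9.7-fold lower number from compound 2 to compound 4 (0.99 log units; beyond the scatter) in this assay. Going by these compounds alone, the direction of the step carried from one core to the other, but its size did not: the same change on two cores in this assay, a 3.3-fold lower number (0.51 log units; beyond the scatter) from compound 3 to compound 1 and a 9.7-fold lower number (0.99 log units; beyond the scatter) from compound 2 to compound 4, 3.0-fold (0.47 log units) apart, beyond the scatter of two such steps With only two pairs, this shows that the size of the step differed between these two cores, but it does not explain the difference or predict the size on any third core.

The compounds shown leave open whether methyl or a longer chain ending in a nitrile, placed on the same oxygen, would give a step of similar size. They also leave open how the change would read on a core carrying chlorine instead of fluorine.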